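The compounds below may be only part of what the source reports. "The series", "measured", "known", "first", "only" and "open" are said of these compounds alone.

Compound 3, `Cc1nc(S(C)(=O)=O)ccc1Oc1ncnc(OC2CCN(C(=O)SC3(C)CC3)CC2)c1F`, gives 166 nM in a functional assay on isolated protein for inhibition of Glucose-dependent insulinotropic receptor (Rattus norvegicus), read by HTRF and cAMP accumulation; a higher number here means that more compound is needed for the effect, a lower number that less compound is needed; it stands second highest of the three numbers, nearer to compound 1, `Cc1nc(S(C)(=O)=O)ccc1Oc1ncnc(OC2CCN(C(=O)OC(C)(C)C(F)(F)F)CC2)c1F`, which gives 47.2 nM, than to compound 2, `Cc1nc(S(C)(=O)=O)ccc1Oc1ncnc(OC2CCN(C(=O)OC3COC3)CC2)c1F`, which gives 2500 nM. Compound 4, `Cc1nc(S(C)(=O)=O)ccc1Oc1ncnc(OC2CCN(C(=O)c3nc(C(C)(C)F)no3)CC2)c1F`, differs from compound 3 by a group of 9 heavy atoms (5 carbon, 2 nitrogen, 1 oxygen, 1 fluorine; one five-membered aromatic ring with 3 hetero atoms) in place of a group of 5 heavy atoms (4 carbon, 1 sulfur; one three-membered non-aromatic ring of carbon only), on a carbonyl carbon. Within the data shown here, two steps bear on the same carbonyl carbon: a 3.5-fold higher number from compound 1 to compound 3 (0.55 log units; beyond the scatter) and a 15-fold lower number from compound 2 to compound 3 (1.18 log units; beyond the scatter), and together with a 53-fold higher number from compound 1 to compound 2 (1.72 log units; beyond the scatter) they show that groups here move the number over a wide span in both directions. The entering group resembles neither earlier one, so the direction is uncertain, but compound 4 is expected to give a somewhat lower number, a 2.8-fold lower number from compound 3 to compound 4 (0.44 log units; beyond the scatter). Compound 4 is therefore estimated at 60 nM, with a range from 12 nM to 300 nM.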

Compound 4, half-maximal effective concentration: 606 nM
The estimate for compound 4 lay 10-fold (1.00 log units) below the measured number; the whole stated range lies below it.
By their numbers in this assay, from the lowest: compound 1; then compound 3; then compound 4; then compound 2.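

In this assay, the five-membered aromatic ring group falls inside the span set by the earlier groups: a 3.7-fold higher number from compound 3 to compound 4 (0.56 log units; beyond the scatter), a 4.1-fold lower number from compound 2 to compound 4 (0.62 log units; beyond the scatter) and a 13-fold higher number from compound 1 to compound 4 (1.11 log units; beyond the scatter). Heavy-atom count does not order the numbers at this carbonyl carbon, since the group of 9 heavy atoms stands above the 5-atom group of compound 3 but below the 5-atom group of compound 2. Nothing measured here explains this placing. The compounds shown leave open whether the ring or its fluorine-bearing substituent sets the number of compound 4, and how a methyl or a tert-butyl on that ring would compare.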